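Lengthening the Acyl Chain in a Weakly Cytotoxic Series

The compounds below may be only part of what the source reports. "The series", "measured", "known", "first", "only" and "open" are said of these compounds alone.

Compound 1 `O=C(Nc1cc(C(F)(F)F)cc(C(F)(F)F)c1)C1CCc2ccccc2N1C(=O)c1ccccc1Cl`: in a functional assay on MDA-MB-231 cells (Homo sapiens) for cytotoxicity, read by sulforhodamine B assay, with a stated time of 72 h (on this read-out higher numbers stand for weaker inhibition of growth and lower numbers for stronger inhibition of growth), compound 1 gives 5250 nM.
Compound 2 `CC(=O)N1c2ccccc2CCC1C(=O)Nc1ccccc1O`: compound 2 gives 89600 nM.
Compound 3 `CC(=O)N1c2ccccc2CCC1C(=O)Nc1cc(C(F)(F)F)cc(C(F)(F)F)c1`: compound 3 reaches only the assay's limit, > 70000 nM.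

Compound 3 stands at the edge of what this assay can report; its entry is the limit of > 70000 nM in this assay, at which 1 of the 3 values shown sits, a boundary of the assay and not a measured number. Compound 4 `CCCC(=O)N1c2ccccc2CCC1C(=O)Nc1cc(C(F)(F)F)cc(C(F)(F)F)c1` differs from compound 3 by ethyl in place of hydrogen on a saturated chain carbon bound to a carbonyl carbon. For the measured compounds named here, only one measured step touches that carbonyl on the shared core: an at least 13-fold higher number from compound 1 to compound 3 (1.12 log units; beyond the scatter), a change in the opposite direction. Compound 2 also carries the acetyl group, and compound 2 gives 89600 nM. Growing methyl to propyl restores only part of the size that the chlorophenyl group provided, so the step of an at least 1.1-fold lower number from compound 3 to compound 4 (0.06 log units; that floor lies within the scatter) is expected to be modest, with a fair chance that only a limit is reported again. Compound 4 is therefore estimated at 60000 nM, in the range 15000 nM to 200000 nM.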

Compound 4, concentration for 50% growth inhibition: 15200 nM
Beside the measured number, compound 4's estimate is 3.9-fold (0.60 log units) above it; the range from low to high includes it.
By their numbers in this assay, from the lowest: compound 1; then compound 4; then compound 2.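

Ethyl in place of hydrogen on a saturated chain carbon bound to a carbonyl carbon, which turns acetyl into propylcarbonyl, gives a clear change in this assay: an at least 4.6-fold lower number from compound 3 to compound 4 (0.66 log units; beyond the scatter). The entry for compound 3 is a limit of the assay and not a number, so this step is only a floor and its true size stays unknown: the limit of > 70000 nM in this assay, at which 1 of the 4 values shown sits.

A plain chain with no ring at this carbonyl can therefore bring back much of the growth inhibition, but not all of it, as propyl in place of 2-chlorophenyl still gives a 2.9-fold higher number from compound 1 to compound 4 (0.46 log units; beyond the scatter).

As far as these compounds go, a single step cannot show how the number follows chain length, so it remains open whether a longer chain such as hexyl would lower it further. Also open, from the compounds shown here alone, is how a chain ending in an amine or a carboxylic acid would behave at this position.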